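Adding a Second Trifluoromethyl to a Urea Inhibitor

A few compounds are considered here, and "the series" means these few. Any claim that something is new, unique, unknown or untested is made for them only; others in the source may bear on it.

Compound 1 `COc1cc(Cl)cc(-c2nn(-c3cccc(NC(=O)Nc4cccc(C(F)(F)F)c4)c3)cc2-c2ccncc2)c1` was tested in a functional assay on SF-268 cells (Homo sapiens) for inhibition, read by sulforhodamine B assay, with a stated time of 48 h, tested at 0.01 uM; a higher number here means a weaker effect of the compound at the concentration tested, a lower number a stronger effect. Compound 1 gives 97%, the lower of two measured numbers, with compound 2 `COc1cc(Cl)cc(-c2nn(-c3cccc(NC(=O)c4cccc(C(F)(F)F)c4)c3)cc2-c2ccncc2)c1` giving 101%, a difference within the scatter. The change from compound 1 to compound 3 `COc1cc(Cl)cc(-c2nn(-c3cccc(NC(=O)Nc4cc(C(F)(F)F)cc(C(F)(F)F)c4)c3)cc2-c2ccncc2)c1` is trifluoromethyl in place of hydrogen on an aromatic carbon. Going by the values given here, the only measured step, a number 4 percentage points higher from compound 1 to compound 2 (within the scatter), concerns a different part of the molecule and stayed within the scatter, so no measured step bears directly on this change. No step beyond the scatter is expected, a number 1 percentage points lower from compound 1 to compound 3 (within the scatter). Compound 3 is estimated at 96%, in the range 84% to 106%.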

Compound 3, a percentage reported as activity, at one concentration (the size of the read-out at that concentration, not a potency): 97%
Compound 3: the middle estimate sits 1 percentage points below what was measured; the measured number falls inside the stated range.
By their numbers in this assay, from the lowest: compounds 1, 3 and 2 (each within the scatter of the next).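

With trifluoromethyl in place of hydrogen on this aromatic carbon, meta to a trifluoromethyl group, the result is no change at the digits printed from compound 1 to compound 3 (within the scatter) in this assay. The earlier step concerned only the urea link, whereas this one shows that the ring itself can carry four more heavy atoms with no readable shift at the one concentration tested. Nothing available explains this outcome.

Going by these compounds, whether an amine or a carboxylic acid on this carbon would read any differently stays open. So does the behaviour of compound 3 at higher concentrations.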